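A Bromine for Fluorine on the Thioether Ring

The source may report more compounds than this note shows. Statements on the series, on what has been measured and on what is new or still open speak of the compounds shown alone.

Compound 2 `CC(O)(CSc1ccc(F)cc1)c1nc(-c2ccccc2)no1` carries an unsubstituted phenyl on its oxadiazole side and a fluoro on the thioether ring. In a functional assay on DU-145 cells (Homo sapiens) for cytotoxicity, read by MTT assay (a lower number here means a stronger inhibitor, a higher number a weaker inhibitor), compound 2 gives only a limit, > 100000 nM. Compound 1 `CC(O)(CSc1ccc(F)cc1)c1nc(-c2ccc(Cl)cc2)no1` is its chloro analogue, and in this assay compound 1 gives 36300 nM, a weak but measurable number. The single-point step an at least 2.7-fold higher number from compound 1 to compound 2 (0.44 log units; beyond the scatter) thus moves from that number up to the limit of > 100000 nM in this assay, at which 2 of the 3 values shown sit. Compound 3 `CC(O)(CS(=O)(=O)c1ccc(F)cc1)c1nc(-c2ccc(F)c(Cl)c2)no1`, a sulfone with a different aryl substitution, is the third member; in this assay compound 3 gives only a limit, > 100000 nM. So compound 2 sits at the weak end of a set in which two of three values are limits rather than numbers.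

Compound 4 `CC(O)(CSc1ccc(Br)cc1)c1nc(-c2ccccc2)no1` differs from compound 2 by bromo in place of fluoro on an aromatic carbon. Among the measured compounds shown here, no measured step touches this ring; the only step recorded, an at least 2.7-fold higher number from compound 1 to compound 2 (0.44 log units; beyond the scatter), concerns the other aromatic ring and was at least modest. For the measured compounds named here, there is therefore no direct precedent for the halogen swap, and with compound 2 already at the limit the expectation for the step of a number no higher from compound 2 to compound 4 (the limit leaves the size open) is that it stays within the scatter, with a large chance of another limit. Compound 4 is accordingly expected to give 100000 nM, within a range of 30000 nM to 300000 nM.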

Compound 4, half-maximal inhibitory concentration: > 100000 nM
Compound 4 was reported as a limit (the forecaster's own chance of this, stated with the estimate: 70%); the middle value sits exactly at the limit.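

In this assay compound 4 gives only a limit, > 100000 nM. Compound 2 also gives only a limit, so the step between compound 2 and compound 4 cannot be read, and both join the compounds at that limit: the limit of > 100000 nM in this assay, at which 3 of the 4 values shown sit. The compounds shown leave open how 4-fluorophenyl and 4-bromophenyl compare where a measurable number exists.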